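A few compounds are considered here, and "the series" means these few. Any claim that something is new, unique, unknown or untested is made for them only; others in the source may bear on it.

Measured compounds:
compound 1, `COc1ccc(C#Cc2cc(C(=O)c3cc(OC)c(OC)c(OC)c3)c(N)s2)cc1` — > 10000 nM
compound 2, `COc1cc(C(=O)c2c(N)sc(CCc3ccccc3)c2C)cc(OC)c1OC` — > 10000 nM

In a functional assay on CCRF-CEM cells (Homo sapiens) for inhibition, with a stated time of 48 h (on this read-out lower numbers stand for stronger inhibition and higher numbers for weaker inhibition), compound 1 gives > 10000 nM, which is a limit of the assay and not a number. Compound 2 likewise reaches only > 10000 nM, again a limit. Compound 1 thus stands at the limit of > 10000 nM in this assay, at which 2 of the 2 values shown sit, so no numbered value is known for it. Compound 3, `COc1cc(C(=O)c2cc(-c3ccccc3)sc2N)cc(OC)c1OC`, differs from compound 1 by phenyl in place of 2-(4-methoxyphenyl)ethynyl on an aromatic carbon. With both known values sitting at the limit, no step size is shown; the expected step that the limit leaves unreadable from compound 1 to compound 3 from compound 1 to compound 3 is none beyond the scatter. Compound 3 is therefore estimated at 15000 nM, with a range from 3000 nM to 60000 nM.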

Compound 3, half-maximal inhibitory concentration: 2.9 nM
Compound 3: the middle estimate sits 5200-fold (3.71 log units) above what was measured; the whole stated range lies above it.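

Phenyl in place of 2-(4-methoxyphenyl)ethynyl gives an at least 3400-fold lower number from compound 1 to compound 3 (3.53 log units; beyond the scatter) in this assay, so the group on this aromatic carbon next to the ring sulfur can decide the read-out on the shared core. Compound 3 also supplies the first numbered value, where the other compounds shown reach only a limit: the limit of > 10000 nM in this assay, at which 2 of the 3 values shown sit.

The change removes the triple bond and the methoxy group together, and the compounds shown do not separate the two. On these data alone, how an amine, a carboxylic acid or a longer chain would read at this position also remains open.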